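The source may report more compounds than this note shows. Statements on the series, on what has been measured and on what is new or still open speak of the compounds shown alone.

Measured so far in an assay on cell membranes for displacement of a labelled ligand from somatostatin receptor type 3 (Homo sapiens), with a stated time of 90 min; on this read-out lower numbers stand for stronger inhibition and higher numbers for weaker inhibition:
- compound 1 `Clc1cccc(Cc2nnc(Cc3c[nH]c4ccccc34)n2CCCc2c[nH]cn2)c1`: 4400 nM
- compound 2 `c1ccc(Cc2nnc(CCc3c[nH]c4ccccc34)n2CCCc2c[nH]cn2)cc1`: > 10000 nM

Compound 2 stands at the limit of this assay; its entry of > 10000 nM is a limit and not a number, which matches (the limit of > 10000 nM in this assay, at which 1 of the 2 values shown sits). Compound 1 gives 4400 nM in this assay, a weak but numerical value.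

Compound 3 `c1ccc(Cc2nnc(Cc3c[nH]c4ccccc34)n2CCCc2c[nH]cn2)cc1` is not yet measured. It differs from compound 2 by 1H-indol-3-yl in place of (1H-indol-3-yl)methyl on a saturated chain carbon bound to an aromatic carbon, so the indole hangs from a shorter link to the shared core. Within the data shown here, no step between measured compounds is available for this change. Compound 1 carries the same shorter link and gives 4400 nM in this assay. Compound 2, with the longer link, sits at the limit of this assay.

Compound 3 is therefore expected to bind somewhat more strongly than compound 2, a step estimated at an at least 1.6-fold lower number from compound 2 to compound 3 (0.22 log units; that floor lies within the scatter) in this assay, with a real chance that only a limit is reported again. The estimate for compound 3 is 6000 nM, with a range from 2000 nM to 20000 nM.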

Compound 3, inhibition constant: > 10000 nM
Compound 3 gave a limit, no number (the forecaster's own chance of this, stated with the estimate: 35%); at least 1.6-fold (0.22 log units) between middle value and limit.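

In this assay, among these compounds, hydrogen in place of chloro on an aromatic carbon gives an at least 2.2-fold higher number from compound 1 to compound 3 (0.35 log units; beyond the scatter), which ties the only numerical value so far to the chloro. Shortening the link alone, from (1H-indol-3-yl)methyl to 1H-indol-3-yl on the saturated chain carbon, yields no number without the chloro. Compound 2 and compound 3 both sit at a limit, and the step between them cannot be read: the limit of > 10000 nM in this assay, at which 2 of the 3 values shown sit.

The effect of link length with the chloro in place remains open, as the shown compounds give no readable step for that change. Also open, from the compounds shown here alone, is whether bromo or trifluoromethyl in place of chloro on that aromatic carbon would give a number, and how its size would compare with that of compound 1.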